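A few compounds are considered here, and "the series" means these few. Any claim that something is new, unique, unknown or untested is made for them only; others in the source may bear on it.

Measured in a functional assay on B16-F10 cells (Mus musculus) for antiproliferative activity, read by CCK-8 assay, with a stated time of 48 h; on this read-out lower numbers stand for stronger inhibition and higher numbers for weaker inhibition:
- compound 1 `COc1ccc(/C=C\c2cc(OC)c(OC)c(OC)c2)cc1OCc1ccc(CN2CCCC[C@H]2C(=O)O)cc1`: > 10000 nM (a limit of the assay, not a number)
- compound 2 `COc1ccc(/C=C\c2cc(OC)c(OC)c(OC)c2)cc1OCc1ccc(CN2CC[C@H](C(=O)O)C2)cc1`: 7000 nM
- compound 3 `COc1ccc(/C=C\c2cc(OC)c(OC)c(OC)c2)cc1OCc1ccc(CO)cc1`: 6600 nM

Compound 3 gives 6600 nM and compound 2 gives 7000 nM, so these two values lie within the scatter of each other. Compound 1 gives only a limit.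

The next compound is compound 4 `COc1ccc(/C=C\c2cc(OC)c(OC)c(OC)c2)cc1OCc1ccc(CN2CC[C@H](O)C2)cc1`. It is made from compound 3 by the change (3-hydroxypyrrolidin-1-yl in place of hydroxy on a saturated chain carbon bound to an aromatic carbon), which places 3-hydroxypyrrolidin-1-yl on the saturated chain carbon that carried hydroxy.

The closest measured evidence is a 1.1-fold lower number from compound 2 to compound 3 (0.03 log units; within the scatter), an exchange at the same carbon between hydroxy and 3-carboxypyrrolidin-1-yl. The other two steps, an at least 1.4-fold lower number from compound 1 to compound 2 (0.15 log units; that floor lies within the scatter) and an at least 1.5-fold lower number from compound 1 to compound 3 (0.18 log units; that floor lies within the scatter), rest on a limit and also stay within the scatter. None of these steps shows a clear effect of the group at this carbon, so no step beyond the scatter is expected in this assay.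

The estimated change is a 1.1-fold lower number from compound 3 to compound 4 (0.04 log units; within the scatter). Compound 4 is expected at 6000 nM, with an estimated range of 2000 nM to 10000 nM.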

Compound 4, half-maximal inhibitory concentration: > 10000 nM
Compound 4: a limit, no number; the forecaster's own chance of this, stated with the estimate: 15%; middle value at least 1.6-fold (0.22 log units) away from the limit.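

In this assay compound 4 gives only a limit, > 10000 nM, and not a number. Placing 3-hydroxypyrrolidin-1-yl where hydroxy stood on the saturated chain carbon gives an at least 1.5-fold higher number from compound 3 to compound 4 (0.18 log units; that floor lies within the scatter), and placing hydroxy where carboxy stood on the saturated ring carbon gives an at least 1.4-fold higher number from compound 2 to compound 4 (0.15 log units; that floor lies within the scatter), so neither change yields a measured gain in this assay, though neither floor goes beyond the scatter. The step from compound 1 to compound 4 cannot be read, and the same limit now appears for a compound without a carboxy group as well as for compound 1, which carries one: the limit of > 10000 nM in this assay, at which 2 of the 4 values shown sit.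

The compounds shown leave open how a plain pyrrolidin-1-yl without hydroxy, or a simple primary amine, would read at this carbon. Going by these compounds, with limits in place of numbers for compound 1 and compound 4, the true size of their steps also stays unknown.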